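Arylsulfonyl variation in a piperazinyl indazole series

This account rests on a few compounds, and the source may have more. Where it says the series, first, only, none or still open, it means among the compounds named here.

Three compounds of this series carry a measured value. Compound 1 `CCCn1nc(S(=O)(=O)c2cccc3ccccc23)c2cc(N3CCNCC3)ccc21` gives 2.2 nM in an assay on HeLa cells for displacement of a labelled ligand from 5-hydroxytryptamine receptor 6 (Homo sapiens); on this read-out lower numbers stand for stronger inhibition and higher numbers for weaker inhibition. Compound 2 `CN1CCN(c2ccc3[nH]nc(S(=O)(=O)c4ccc(F)cc4)c3c2)CC1` gives 5.2 nM, and compound 3 `O=S(=O)(c1ccc(Cl)cc1)c1n[nH]c2cc(N3CCNCC3)ccc12` gives 110 nM. Compound 2 therefore holds the second highest of the three numbers: compound 1 sits at a lower number, beyond the usual scatter, and compound 3 sits far higher, also well beyond the scatter.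

Compound 4 `CN1CCN(c2ccc3[nH]nc(S(=O)(=O)c4c(Cl)cccc4Cl)c3c2)CC1` has not been measured yet. It differs from compound 2 in one place only: 2,6-dichlorophenyl in place of 4-fluorophenyl on a sulfonyl sulfur. Going by the values given here, no measured pair isolates a change on the aryl group of the sulfonyl sulfur, so the size of the step is open; the spread between compound 2 at 5.2 nM and compound 3 at 110 nM shows that this region of the molecule can move the number a long way. A moderate weakening is expected, so that the step of a 2.9-fold higher number from compound 2 to compound 4 (0.46 log units; beyond the scatter) goes toward a higher number, beyond the scatter. Compound 4 is estimated at 15 nM, within a range from 3 nM to 100 nM.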

Compound 4, inhibition constant: 2.6 nM
Beside the measured number, compound 4's estimate is 5.8-fold (0.76 log units) above it; measured number outside the range, below it.
By their numbers in this assay, from the lowest: compounds 1, 4 and 2 (each within the scatter of the next, the first and the last beyond it); then compound 3.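

In this assay, going by these compounds alone, this is the first pair that isolates the aryl group on the sulfonyl sulfur, and it gives a 2.0-fold lower number from compound 2 to compound 4 (0.30 log units; within the scatter). With the rest of the molecule held fixed, 2,6-dichlorophenyl and 4-fluorophenyl are therefore not separated by this read-out, so this position accepts the exchange of one halogen-bearing phenyl for the other without a change beyond the scatter. No supporting data bear on the reason for this result.

Still open, from the compounds shown here alone, is how this position responds to a phenyl carrying an amine or a carboxylic acid, or to an alkyl chain in place of the aryl group on the sulfonyl sulfur. Also open, going by these compounds, is whether the same exchange gives a similar step on the core of compound 3.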